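Methoxy for Chloro on the Anilino Ring

The source may report more compounds than this note shows. Statements on the series, on what has been measured and on what is new or still open speak of the compounds shown alone.

Measured so far:
compound 1, `COc1ccc(N/C=C\C(=O)c2cn(-c3ccccc3)nc2-c2ccc(F)cc2)cc1`, 4600 nM
compound 2, `O=C(/C=C\Nc1ccc(Cl)cc1)c1cn(-c2ccccc2)nc1-c1ccc(Cl)cc1`, 3890 nM

In a functional assay on PC-3 cells (Homo sapiens) for antiproliferative activity, read by MTT assay, with a stated time of 48 h (a lower number here means a stronger inhibitor, a higher number a weaker inhibitor), compound 1 gives 4600 nM and compound 2 gives 3890 nM; the two values sit within the usual scatter of each other, so neither stands apart. Compound 3, `COc1ccc(N/C=C\C(=O)c2cn(-c3ccccc3)nc2-c2ccc(Cl)cc2)cc1`, has not yet been measured. It differs from compound 2 in one place: methoxy in place of chloro on an aromatic carbon. Nothing measured here isolates this change. Compound 1, which also carries the methoxy, gives a value near that of compound 2, so the step of a 1.1-fold higher number from compound 2 to compound 3 (0.03 log units; within the scatter) is expected to stay within the scatter. Compound 3 is estimated at 4200 nM, between 2000 nM and 9000 nM.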

Compound 3, half-maximal inhibitory concentration: 10700 nM
For compound 3 the middle estimate is 2.5-fold (0.41 log units) below the measured one, outside the stated range (above it).
By their numbers in this assay, from the lowest: compounds 2 and 1 (each within the scatter of the next); then compound 3.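

In this assay, within the data shown here, methoxy in place of chloro on the anilino ring is not neutral: a 2.8-fold higher number from compound 2 to compound 3 (0.44 log units; beyond the scatter) is a modest weakening that the earlier compounds could not isolate. With the methoxy held fixed, the halogen on the other aromatic ring also matters, as a 2.3-fold higher number from compound 1 to compound 3 (0.37 log units; beyond the scatter) shows when chloro replaces fluoro. No measurement given here explains either step. Still open, as far as these compounds go, is whether an amine or a trifluoromethyl group at the methoxy position would follow the chloro or the methoxy compound. From the compounds shown here alone, whether the halogen step holds with chloro on the anilino ring also remains open.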